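Acetyl to Amino: Expecting the Next Measurement

The compounds below may be only part of what the source reports. "The series", "measured", "known", "first", "only" and "open" are said of these compounds alone.

Measured so far in a functional assay on HeLa cells (Homo sapiens) for antiproliferative activity, read by cell counting, with a stated time of 3 days; a higher number here means a weaker inhibitor, a lower number a stronger inhibitor:
compound 1 `CC(Nc1ccccc1Oc1ccc(Cl)cc1)=C1C(=O)CC(c2ccccc2)CC1=O` gives 500 nM
compound 2 `CC(=O)c1ccc(Oc2ccccc2NC(C)=C2C(=O)CC(c3ccccc3)CC2=O)cc1` gives 130 nM
compound 3 `CC(Nc1ccccc1Oc1ccc(C(C)O)cc1)=C1C(=O)CC(c2ccccc2)CC1=O` gives 75 nM

All three share one core and differ only in the group on the same aromatic carbon. Compound 2, which carries an acetyl there, stands second of the three numbers in this assay: compound 1 sits clearly higher, since a 3.8-fold lower number from compound 1 to compound 2 (0.59 log units; beyond the scatter) is beyond the scatter, while compound 3 sits only a little lower, as a 1.7-fold lower number from compound 2 to compound 3 (0.24 log units; within the scatter) stays within the scatter, so no order between compound 2 and compound 3 can be claimed.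

Compound 4 `CC(Nc1ccccc1Oc1ccc(N)cc1)=C1C(=O)CC(c2ccccc2)CC1=O` is the next variant on that carbon: amino in place of acetyl on an aromatic carbon

Within the data shown here, two measured steps bear on this change. The swap of chloro for acetyl gave a 3.8-fold lower number from compound 1 to compound 2 (0.59 log units; beyond the scatter), a modest gain; the swap of acetyl for 1-hydroxyethyl gave a 1.7-fold lower number from compound 2 to compound 3 (0.24 log units; within the scatter), within the scatter. Replacing acetyl by another small group on this carbon has therefore produced at most a modest shift, and in this assay a step of a 1.1-fold lower number from compound 2 to compound 4 (0.03 log units; within the scatter) is expected, without clear direction. Compound 4 is accordingly estimated at 120 nM, in a range from 40 nM to 400 nM.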

Compound 4, half-maximal inhibitory concentration: 39 nM
For compound 4 the middle estimate is 3.1-fold (0.49 log units) above the measured one; measured number outside the range, below it.
By their numbers in this assay, from the lowest: compounds 4, 3 and 2 (each within the scatter of the next, the first and the last beyond it); then compound 1.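

In this assay, a group much smaller than acetyl, with one heavy atom in place of three and one hydrogen-bond donor where acetyl has none, gives a real gain at this carbon: a 3.3-fold lower number from compound 2 to compound 4 (0.52 log units; beyond the scatter), a step beyond the scatter, whereas the earlier change from acetyl to 1-hydroxyethyl stayed within it. Among these compounds, the position also proves more sensitive than the earlier compounds showed, since the span across the series now reaches a 13-fold lower number from compound 1 to compound 4 (1.11 log units; beyond the scatter), a large step that separates amino clearly from chloro. Amino cannot, however, be ranked against 1-hydroxyethyl, because a 1.9-fold lower number from compound 3 to compound 4 (0.28 log units; within the scatter) stays within the scatter, and so compound 3 lies close to both compound 2 and compound 4 while only those two stand clearly apart.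

No measurement shown here explains why amino and acetyl differ on this carbon. On these data alone, it remains open whether a larger nitrogen group, such as dimethylamino or acetamide, or a different small group, such as hydroxyl or a carboxylic acid, would give a number close to that of compound 4 or a much higher one.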